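This account rests on a few compounds, and the source may have more. Where it says the series, first, only, none or still open, it means among the compounds named here.

Results so far in a functional assay on HepG2 cells (Homo sapiens) for antiproliferative activity, read by MTT assay, with a stated time of 72 h (on this read-out lower numbers stand for stronger inhibition and higher numbers for weaker inhibition), are these.
- Compound 1 `O=C(N/N=C/c1cccc(Cl)c1Cl)Nc1ccc(Oc2ccnc3[nH]ccc23)c(F)c1` gives "not active" (no number reported)
- Compound 2 `O=C(N/N=C/c1ccccc1)Nc1ccc(Oc2ccnc3[nH]ccc23)cc1` gives 750 nM
- Compound 3 `O=C(N/N=C/c1ccc([N+](=O)[O-])cc1)Nc1ccc(Oc2ccnc3[nH]ccc23)cc1` gives 4620 nM

Of the two compounds with a number, compound 3 stands highest at 4620 nM and so shows the weaker inhibition of that pair. Compound 1 has no number to compare.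

The open question is compound 4 `O=C(N/N=C/c1cccc(Cl)c1Cl)Nc1ccc(Oc2ccnc3[nH]ccc23)cc1` with this change: 2,3-dichlorophenyl in place of 4-nitrophenyl on a carbon with a double bond to nitrogen. In words, 2,3-dichlorophenyl comes in place of 4-nitrophenyl on a carbon with a double bond to nitrogen.

For the measured compounds named here, the only measured step is a 6.2-fold higher number from compound 2 to compound 3 (0.79 log units; beyond the scatter) and it puts nitro in place of hydrogen on an aromatic carbon. That step shows how far one change has moved the number here, but it is not the same swap, so it gives only a rough scale. Compound 1 carries the same 2,3-dichlorophenyl group and gives "not active" (no number reported) on a core that is not identical to that of compound 4, which argues against expecting a large gain.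

The estimated change is a 1.3-fold lower number from compound 3 to compound 4 (0.12 log units; within the scatter) and so no step beyond the scatter is expected. For compound 4 the estimate is 3500 nM with 700 nM to 15000 nM as its expected range.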

Compound 4, half-maximal inhibitory concentration: "not active" (no number reported)
Compound 4 has no reported number here, so the estimate cannot be set against anything.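

For the compounds shown here, compound 4 has no reported number, so no step from compound 3 to compound 4 can be read. No supporting evidence bears on this result. The compounds shown leave open how the 2,3-dichlorophenyl group compares with phenyl or 4-nitrophenyl on the shared core, and compound 1, which carries the same group, offers no number either.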